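This account rests on a few compounds, and the source may have more. Where it says the series, first, only, none or still open, it means among the compounds named here.

Of the compounds shown here, three from this study have already been measured in a functional assay on K562 cells (Homo sapiens) for cytotoxicity, read by MTT assay; a higher number here means a weaker inhibitor, a lower number a stronger inhibitor. Compound 1 `CO[C@@H]1OC[C@]2(C)CCC[C@]3(COC(=O)[C@@]45C[C@@H](CC[C@H]43)[C@H](C)C5=O)[C@H]12` reaches in this assay only the assay limit of > 50 ug/mL, which is not a number. Compound 2 `C=C1C(=O)[C@]23C[C@H]1CC[C@H]2[C@@]1(CCC[C@@]2(C)CO[C@@H](OC)[C@H]21)COC3=O` gives in this assay a value of 0.18 ug/mL. Compound 3 `C[C@H]1C(=O)[C@]23C[C@H]1CC[C@H]2[C@@]1(CCC[C@@]2(C)COC(=O)[C@H]21)COC3=O`, the starting point of this step, likewise returns in this assay only the limit of > 50 ug/mL, so that no number is known for it. Compound 3 therefore stands at the limit of > 50 ug/mL in this assay, at which 2 of the 3 values shown sit. For the measured compounds named here, compound 2 is the single compound among the three with a measured value. The move to compound 4 `C[C@H]1C(=O)[C@]23C[C@H]1C[C@@H](O)[C@H]2[C@@]1(CCC[C@@]2(C)COC(=O)[C@H]21)COC3=O` consists of hydroxy in place of hydrogen on a saturated ring carbon, the rest of the core of compound 3 being kept. Going by the values given here, no single-change step between measured compounds is recorded, so the measured pairs give no guide to the effect of this addition. The step of a number no higher from compound 3 to compound 4 (the limit leaves the size open) is expected to be small, within the scatter, so that compound 4 stays near the limit. Compound 4 is accordingly estimated at 50 ug/mL, with a range from 20 ug/mL to 120 ug/mL, and the assay will likely again report only a limit.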

Compound 4, half-maximal inhibitory concentration: > 50 ug/mL
Compound 4 gave a limit, no number; the forecaster's own chance of this, stated with the estimate: 75%; the middle value lies on the limit itself.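

In this assay compound 4, like compound 3, gives only a limit, so no step can be read between compound 3 and compound 4. The compounds shown leave open whether hydroxy in place of hydrogen on a saturated ring carbon changes this read-out at all, as most values share one limit: the limit of > 50 ug/mL in this assay, at which 3 of the 4 values shown sit.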